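The source may report more compounds than this note shows. Statements on the series, on what has been measured and on what is new or still open speak of the compounds shown alone.

Compound 1 `CCCC(C)n1c(CC)nc2c(-c3ccc(Cl)cc3C(C)=O)ccnc21` gives 95.6 nM in an assay for binding affinity to Corticotropin releasing factor receptor (Rattus norvegicus); on this read-out higher numbers stand for weaker inhibition and lower numbers for stronger inhibition.
Compound 2 `CCc1nc2c(-c3ccc(Cl)cc3Cl)ccnc2n1[C@H](C)C1CC1` gives 0.6 nM in this assay.

Compound 2 stands lowest of the two numbers; compound 1 lies far from it, beyond the scatter. Compound 3 `CCCC(C)n1c(CC)nc2c(-c3ccc(Cl)cc3Cl)ccnc21` keeps the core and both chlorines of compound 2 and changes only the group on the nitrogen: 1-methylbutyl in place of 1-cyclopropylethyl on an aromatic nitrogen. Among the compounds with values here, no measured pair isolates this change, so the step is uncertain; a modest rise is expected, with no step beyond the scatter also plausible. For compound 3 in this assay the estimate is 2 nM, spanning 0.5 nM to 8 nM, a step of a 3.3-fold higher number from compound 2 to compound 3 (0.52 log units; beyond the scatter) that is expected.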

Compound 3, inhibition constant: 0.5 nM
Beside the measured number, compound 3's estimate is 4.0-fold (0.60 log units) above it; low and high end bracket the measured number.
By their numbers in this assay, from the lowest: compounds 3 and 2 (each within the scatter of the next); then compound 1.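

In this assay, 1-methylbutyl in place of 1-cyclopropylethyl on the aromatic nitrogen gives a 1.2-fold lower number from compound 2 to compound 3 (0.08 log units; within the scatter) and so shows that, with the rest of compound 2 kept, the open chain and the three-membered ring are not told apart here. Chloro in place of acetyl on an aromatic carbon gives a 190-fold lower number from compound 1 to compound 3 (2.28 log units; beyond the scatter) and so ties the large gap to that change, not to the group on the nitrogen. Nothing at hand explains either step. The compounds shown leave open how a cyclobutyl group or a methoxyethyl chain on that nitrogen would read. Methoxy or fluoro in place of that chloro also remains open.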